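This account rests on a few compounds, and the source may have more. Where it says the series, first, only, none or still open, it means among the compounds named here.

In a functional assay on K562 cells (Homo sapiens), read by MTT assay, with a stated time of 72 h (on this read-out lower numbers stand for stronger inhibition and higher numbers for weaker inhibition), compound 2 `CNc1ncnc2c1c(-c1ccco1)cn2[C@@H]1O[C@H](CO)[C@@H](O)[C@H]1O` gives 220 nM, the lowest of the two numbers recorded, while compound 1 `COc1ncnc2c1c(-c1cc3ccccc3o1)cn2[C@@H]1O[C@H](CO)[C@@H](O)[C@H]1O` gives 20900 nM, a gap far beyond the usual scatter. Compound 1 and compound 2 differ in more than one place, so their two values are all that can be said of that pair. Compound 3 `COc1ncnc2c1c(-c1ccco1)cn2[C@@H]1O[C@H](CO)[C@@H](O)[C@H]1O` has not yet been measured in this assay. It differs from compound 2 in a single place: methoxy in place of methylamino on an aromatic carbon. For the measured compounds named here, the change takes away the one hydrogen-bond donor counted at that position, and the only measured methoxy compound, compound 1, gives 20900 nM in this assay, although its second difference from compound 2 leaves that evidence indirect. Compound 3 is therefore expected to show a weaker result, a step of an 11-fold higher number from compound 2 to compound 3 (1.06 log units; beyond the scatter) that lies beyond the scatter. The estimated value of compound 3 is 2500 nM, with a range from 500 nM to 15000 nM.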

Compound 3, half-maximal inhibitory concentration: 60 nM
Compound 3: the middle estimate sits 42-fold (1.62 log units) above what was measured; measured number below the stated range.
By their numbers in this assay, from the lowest: compound 3; then compound 2; then compound 1.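

In this assay the change from methylamino to methoxy on this aromatic carbon, with furan-2-yl kept in place, gives a 3.7-fold lower number from compound 2 to compound 3 (0.56 log units; beyond the scatter) and so runs opposite to the loss of the hydrogen-bond donor: this pair needs no such donor at this position for a low number. With methoxy held constant, furan-2-yl in place of 1-benzofuran-2-yl gives a 350-fold lower number from compound 1 to compound 3 (2.54 log units; beyond the scatter) as a far larger step, so the high number of compound 1 does not go with methoxy as such. No measured evidence is available to explain either step.

The compounds shown leave open how an unsubstituted amine, an ethoxy group or a chlorine atom on the same carbon would compare. They also leave open whether methoxy keeps its edge over methylamino with 1-benzofuran-2-yl on the core, and how a thiophene ring would read in place of furan-2-yl.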